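The source may report more compounds than this note shows. Statements on the series, on what has been measured and on what is new or still open speak of the compounds shown alone.

Measured compounds:
Compound 1 `O=C(CN1CCCC1)N1CCC(NS(=O)(=O)c2cc(S(=O)(=O)c3ccccc3)ccc2C(F)(F)F)CC1` gives 190 nM in a functional assay on U2OS cells for antagonist activity at proto-oncogene Wnt-3 (Homo sapiens), read by a luciferase reporter, with a stated time of 18 h; on this read-out lower numbers stand for an effect already at smaller amounts and higher numbers for an effect only at larger amounts of compound.
Compound 2 `CC(C)(C)OC(=O)N1CCC[C@H]1C(=O)N1CCC(NS(=O)(=O)c2cc(S(=O)(=O)c3ccccc3)ccc2C(F)(F)F)CC1` gives 60 nM in this assay.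
Compound 3 `CCNC(=O)N1CCC[C@H]1C(=O)N1CCC(NS(=O)(=O)c2cc(S(=O)(=O)c3ccccc3)ccc2C(F)(F)F)CC1` gives 90 nM in this assay.

Compound 1 stands highest of the three numbers; its nearest neighbour is compound 3 and its furthest is compound 2. Compound 4 `CC(C)(C)CCN1CCC[C@H]1C(=O)N1CCC(NS(=O)(=O)c2cc(S(=O)(=O)c3ccccc3)ccc2C(F)(F)F)CC1` differs from compound 1 in one place: 1-(3,3-dimethylbutyl)pyrrolidin-2-yl in place of (pyrrolidin-1-yl)methyl on a carbonyl carbon. Within the data shown here, two measured steps bear on this change, both replacing the same group with a 1-substituted pyrrolidin-2-yl: a 3.2-fold lower number from compound 1 to compound 2 (0.50 log units; beyond the scatter) and a 2.1-fold lower number from compound 1 to compound 3 (0.32 log units; beyond the scatter). Both went in the same direction and were modest. Compound 4 is therefore expected to show a step of a 2.4-fold lower number from compound 1 to compound 4 (0.38 log units; beyond the scatter), a modest lowering rather than none. Compound 4 is estimated at 80 nM, within a range from 30 nM to 250 nM.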

Compound 4, half-maximal effective concentration: 450 nM
Compound 4: middle estimate off by 5.6-fold (0.75 log units), on the low side, outside the stated range (above it).
By their numbers in this assay, from the lowest: compounds 2 and 3 (each within the scatter of the next); then compound 1; then compound 4.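

In this assay, a 1-substituted pyrrolidin-2-yl on the carbonyl carbon does not lower the number by itself: with 1-(3,3-dimethylbutyl)pyrrolidin-2-yl the step reverses, giving a 2.4-fold higher number from compound 1 to compound 4 (0.37 log units; beyond the scatter). The group on the amine nitrogen in the ring therefore sets the direction, since 3,3-dimethylbutyl gives a 5.0-fold higher number from compound 3 to compound 4 (0.70 log units; beyond the scatter) in place of ethylcarbamoyl and a 7.5-fold higher number from compound 2 to compound 4 (0.88 log units; beyond the scatter) in place of tert-butoxycarbonyl. Nothing available here accounts for this reversal. The compounds shown leave open whether an acetyl group or a plain ethyl chain on that nitrogen would give numbers like those of compound 2 and compound 3, or like that of compound 4.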